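The source may hold more compounds than are shown below. What is called first, only, known or untested is meant among the compounds shown, and "the series" means these compounds.

Measured so far:
compound 1 `COc1ccccc1-n1c(Nc2nc(-c3ccccc3)cs2)n[nH]c1=S` — 300 mg/kg
compound 2 `S=c1[nH]nc(Nc2nc(-c3ccc(Cl)cc3)cs2)n1-c1ccccc1` — 300 mg/kg

In a functional assay on the whole organism (strain Swiss albino) for inhibition, with Mus musculus as the target, with a stated time of 4 h (on this read-out higher numbers stand for an effect only at larger amounts of compound and lower numbers for an effect already at smaller amounts), compound 2 gives 300 mg/kg; compound 1 gives 300 mg/kg. Compound 2 thus stands level with compound 1 at the digits shown, the difference lying within the scatter of repeated measurements.

Compound 3 `COc1ccccc1-n1c(Nc2nc(-c3ccc(Cl)cc3)cs2)n[nH]c1=S` differs from compound 2 in one place: methoxy in place of hydrogen on an aromatic carbon. Within the data shown here, no step between two measured compounds isolates this change. Compound 1 carries the methoxy and compound 2 does not, but the two also differ elsewhere, so their pair shows only that both give the same minimum effective dose.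

On that basis no shift beyond the scatter is expected for compound 3 in this assay; the step of no change at the digits printed from compound 2 to compound 3 (within the scatter) is estimated as flat. Compound 3 is expected to give 300 mg/kg, with a range from 150 mg/kg to 600 mg/kg.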

Compound 3, minimum effective dose: 100 mg/kg
The estimate for compound 3 lay 3.0-fold (0.48 log units) above the measured number; measured number outside the range, below it.
By their numbers in this assay, from the lowest: compound 3; then compounds 1 and 2 (each within the scatter of the next).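

In this assay, the methoxy on an aromatic carbon, ortho to a large group, gives a 3.0-fold lower number from compound 2 to compound 3 (0.48 log units; beyond the scatter), so the change from phenyl to 2-methoxyphenyl counts at this position when the chloro is present. Chloro in place of hydrogen on an aromatic carbon gives a 3.0-fold lower number from compound 1 to compound 3 (0.48 log units; beyond the scatter), so that change also counts when the methoxy is present, and compound 3, carrying both groups, has the lowest number of the three. No measurement on hand accounts for either step.

From the compounds shown here alone, whether either group would shift the number without the other stays open, as every readable step here ends at compound 3. Also open, going by these compounds, is whether an ethoxy, a hydroxy or an amine at the methoxy position would match the methoxy step.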